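The compounds below may be only part of what the source reports. "The series", "measured", "known", "first", "only" and "open" are said of these compounds alone.

Three compounds share one core and were all run in a functional assay on HeLa cells for antagonist activity at 5-hydroxytryptamine receptor 6 (Homo sapiens), read by cAMP accumulation and immunoassay, with a stated time of 10 min; a lower number here means a smaller maximal response, a higher number a larger maximal response. Compound 1, `COc1cccc(S(=O)(=O)c2cccc3oc(N4CCNCC4)nc23)c1`, gives 92% in this assay. Compound 2, `O=S(=O)(c1cccc2ccccc12)c1cccc2oc(N3CCNCC3)nc12`, gives 97% in this assay. Compound 3, `O=S(=O)(c1cccc2ccccc12)c1cccc2nc(N3CCNCC3)oc12`, gives 96% in this assay. Compound 2 holds the top figure of the three, but compound 3 and compound 1 both fall within the scatter of it, so nothing separates the three: each reaches close to a full maximal response in this assay.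

Compound 4, `CN1CCN(c2nc3c(S(=O)(=O)c4cccc5ccccc45)cccc3o2)CC1`, has not yet been measured. It differs from compound 2 in a single place: methyl in place of hydrogen on an amine nitrogen in a ring. Cut one bond further out, the change reads piperazin-1-yl to 4-methylpiperazin-1-yl.

Going by the values given here, no pair among the measured compounds shows the effect of this change, and the three measured values sit on a narrow band near the reference. Compound 4 is therefore expected to stay in that band, with a step from compound 2 of a number 4 percentage points lower from compound 2 to compound 4 (within the scatter) that does not reach beyond the scatter. Compound 4 is estimated at 93% in this assay, within a range from 80% to 102%.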

Compound 4, largest response reached (reported as Imax), in percent of the reference or control that the assay uses: 83%
The estimate for compound 4 lay 10 percentage points above the measured number, within the range that was stated.
By their numbers in this assay, from the lowest: compounds 4, 1, 3 and 2 (each within the scatter of the next, the first and the last beyond it).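

Replacing hydrogen with methyl on the amine nitrogen in the ring, which turns piperazin-1-yl into 4-methylpiperazin-1-yl, gives in this assay a number 14 percentage points lower from compound 2 to compound 4 (beyond the scatter). The three earlier compounds all carry piperazin-1-yl and sit within the scatter of one another, so they could not show whether this nitrogen matters; this pair shows that a change of a single carbon there can move the maximal response by more than the scatter, though the step is modest and the response remains substantial. Nothing available explains why the added methyl lowers the response.

The compounds shown leave open whether a longer chain such as ethyl, or a group such as acetyl or 2-hydroxyethyl, on this same nitrogen would lower the maximal response further, hold it or restore it. They also leave open whether methyl at this nitrogen would produce a similar step on the cores of compound 1 and compound 3, as the finding rests on a single pair.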